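Adding naphthalen-1-yl to compound 2

A few compounds are considered here, and "the series" means these few. Any claim that something is new, unique, unknown or untested is made for them only; others in the source may bear on it.

Compound 1 `Cn1cc(C2=C(c3nn(CCCN4CCCCC4)c4ncccc34)C(=O)N(c3cccc4ccccc34)C2=O)c2ccccc21` gives 2820 nM
Compound 2 `Cn1cc(C2=C(c3n[nH]c4ncccc34)C(=O)NC2=O)c2ccccc21` gives > 100000 nM

In a functional assay on A549 cells (Homo sapiens) for antiproliferative activity, read by MTT assay, with a stated time of 48 h (a lower number here means a stronger inhibitor, a higher number a weaker inhibitor), compound 2 gives > 100000 nM as a limit of the assay and not a number. Compound 3 `Cn1cc(C2=C(c3n[nH]c4ncccc34)C(=O)N(c3cccc4ccccc34)C2=O)c2ccccc21` carries naphthalen-1-yl in place of hydrogen on an amide-type nitrogen in a ring and is otherwise the same as compound 2. Among the compounds with values here, no measured pair isolates this change. The expectation rests on compound 1, which also bears naphthalen-1-yl and gives 2820 nM in this assay as a measured number. A step of an at least 4.5-fold lower number from compound 2 to compound 3 (0.65 log units; beyond the scatter) is expected, towards stronger inhibition and beyond the scatter. Compound 3 is estimated at 22000 nM with a range from 6000 nM to 80000 nM as the expected span.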

Compound 3, half-maximal inhibitory concentration: > 100000 nM
Compound 3 ended at the assay's limit; the forecaster's own chance of this, stated with the estimate: 20%; middle value at least 4.5-fold (0.65 log units) away from the limit.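

In this assay, naphthalen-1-yl on an amide-type nitrogen in a ring does not bring compound 3 to a measured number, and the step from compound 2 cannot be read, as both ends are limits of the assay. Hydrogen in place of 3-(piperidin-1-yl)propyl on an aromatic nitrogen gives an at least 35-fold higher number from compound 1 to compound 3 (1.54 log units; beyond the scatter). The measured number of compound 1 therefore goes with that chain being present, not with naphthalen-1-yl alone.

How far compound 2 and compound 3 lie past the limit stays open: the limit of > 100000 nM in this assay, at which 2 of the 3 values shown sit.

As far as these compounds go, whether a shorter chain, or a morpholine in place of the piperidine, would keep a measurable number also stays open.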